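The compounds below may be only part of what the source reports. "The series", "measured", "known", "first", "only" and "open" are said of these compounds alone.

Of the compounds shown here, three sharing one core have been tested in a functional assay on Right cardiac atrium for agonist activity at histamine H2 receptor (Cavia porcellus), with a stated time of 30 min, in the presence of a further agent that is not named here; on this read-out higher numbers stand for larger maximal responses and lower numbers for smaller maximal responses. Compound 1 `Cc1nc(N)sc1CCCN/C(N)=N/C(=O)NC(C)c1ccc(Br)cc1` gives 0.87 in this assay. Compound 2 `Cc1nc(N)sc1CCCN/C(N)=N/C(=S)N[C@H](C)c1ccccc1` gives 0.87, level with compound 1 at the digits shown. Compound 3 `CCC(NC(=O)/N=C(\N)NCCCc1sc(N)nc1C)c1ccccc1` gives 0.93, a figure that sits within the usual scatter of compound 1, so these three cannot be told apart on the numbers alone.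

Compound 4 `COc1ccc(C(C)NC(=O)/N=C(\N)NCCCc2sc(N)nc2C)cc1` is not yet measured. It departs from compound 1 by a single change on the outer ring: methoxy in place of bromo on an aromatic carbon. Among the measured compounds every change at this end of the molecule has left the response nearly flat, so the expected step from compound 1 to compound 4 is a number 0.020 higher from compound 1 to compound 4 (within the scatter), none beyond the scatter. Compound 4 is thus estimated at 0.89, between 0.78 and 0.98.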

Compound 4, intrinsic activity: the largest response reached, as a fraction of the reference agonist's: 0.91
Beside the measured number, compound 4's estimate is 0.020 below it, and the stated range covers the measured number.
By their numbers in this assay, from the lowest: compounds 1, 2, 4 and 3 (each within the scatter of the next).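

In this assay, within the data shown here, methoxy in place of bromo gives a number 0.040 higher from compound 1 to compound 4 (within the scatter) and this is the first comparison in the set that isolates a single change. It shows that, at this position on the outer ring, the two groups cannot be told apart by maximal response, even though they differ in their atoms and hydrogen-bond acceptor count. Nothing available explains this result. As far as these compounds go, whether the response would also hold with an amine, a carboxylic acid or a longer alkoxy chain at this position remains open.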